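Opening a Ring in a Sphingosine-1-Phosphate Transporter Series

The source may report more compounds than this note shows. Statements on the series, on what has been measured and on what is new or still open speak of the compounds shown alone.

Measured compounds:
- Compound 1, `CCCCCCCCCCc1ccc(-c2noc(C3CNC3)n2)cc1`: 65%
- Compound 2, `CCCCCCCCCCc1ccc(-c2noc(C3CCNC3)n2)cc1`: 26%
- Compound 3, `CCCCCCCCCCc1ccc(-c2noc([C@@H]3CCCN3)n2)cc1`: 21%

All three compounds share one core and differ only in the small nitrogen-containing ring attached to it. In an assay on HeLa cells for inhibition of sphingosine-1-phosphate transporter SPNS2 (Mus musculus), read by LC-MS, tested at 2 uM (a higher number here means more inhibition at the concentration tested (going by the name of the read-out), a lower number less inhibition), compound 1 gives 65%, and compound 2 stands second highest of the three numbers; its nearest neighbour is compound 3, which lies within the scatter of it, while compound 1 lies far above it.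

Compound 4, `CCCCCCCCCCc1ccc(-c2noc([C@@H](N)CCCN)n2)cc1`, takes the change (1,4-diaminobutyl in place of pyrrolidin-3-yl on an aromatic carbon). The measured steps speak only to ring size and attachment point: a number 39 percentage points lower from compound 1 to compound 2 (beyond the scatter), a number 44 percentage points lower from compound 1 to compound 3 (beyond the scatter), whereas a number 5 percentage points lower from compound 2 to compound 3 (within the scatter). For the measured compounds named here, no measured step opens the ring, so the bearing of these steps is indirect. The two pyrrolidines sit together at the low end, and a change away from this ring has no measured parallel, so the expected step is a number 1 percentage points lower from compound 2 to compound 4 (within the scatter), which means no shift beyond the scatter. For compound 4 the estimated value in this assay is 25%, with a range from 5% to 55%.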

Compound 4, a percentage reported as inhibition, at one concentration (the size of the read-out at that concentration, not a potency): 40%
Estimate against measurement, compound 4: 15 percentage points below, and the stated range covers the measured number.
By their numbers in this assay, from the lowest: compounds 3 and 2 (each within the scatter of the next); then compound 4; then compound 1.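

Opening the ring does not have to cost inhibition at this position. In this assay, 1,4-diaminobutyl in place of pyrrolidin-3-yl gives a number 14 percentage points higher from compound 2 to compound 4 (beyond the scatter), and in place of pyrrolidin-2-yl it gives a number 19 percentage points higher from compound 3 to compound 4 (beyond the scatter), so among these compounds a ring on this aromatic carbon is not required, though the azetidin-3-yl group stays ahead, with a number 25 percentage points lower from compound 1 to compound 4 (beyond the scatter). Nothing available here explains these differences.

From the compounds shown here alone, the step removes the ring and brings in a second amine at once, so the share of each remains open; a butyl chain carrying a single amine would help to separate the two. The mirror-image form of the 1,4-diaminobutyl group, with its one defined stereocentre reversed, also remains an open comparison.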